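The source may report more compounds than this note shows. Statements on the series, on what has been measured and on what is new or still open speak of the compounds shown alone.

Working notes on the series. In an ADME assay on cells (Epithelial cell, Homo sapiens) for antiproliferative activity, read by MTT assay, with a stated time of 48 h (a lower number here means a stronger inhibitor, a higher number a weaker inhibitor), compound 1 `COC(=O)/C(=C/c1ccccc1)CN1C(=O)[C@@H](OC)[C@H]1c1cccc(C(F)(F)F)c1` gives 71800 nM. Compound 2 `COC(=O)/C(=C/c1ccccc1)CN1C(=O)[C@@H](OC)[C@H]1c1ccccc1` is recorded in this assay only as "not toxic" (no number reported), so no single number places it on the scale. Compound 3 `COC(=O)/C(=C/c1ccccc1)CN1C(=O)[C@@H](OC)[C@H]1c1ccccc1C(F)(F)F` differs from compound 2 by trifluoromethyl in place of hydrogen on an aromatic carbon. For the measured compounds named here, no measured step exists for this change, and compound 2 carries no number, so no size or direction of step beyond the scatter can be set in this assay; weak activity remains the working guess because compound 1 gives only 71800 nM. Compound 3 is expected near 80000 nM, within 30000 nM to 200000 nM.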

Compound 3, half-maximal inhibitory concentration: "not toxic" (no number reported)
The entry for compound 3 holds no number, so the estimate cannot be set against anything.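

In this assay compound 2 and compound 3 both stand only as "not toxic", so no step can be read between them. No evidence bears on this result. As far as these compounds go, whether phenyl to 2-(trifluoromethyl)phenyl shifts the read-out by any size stays open.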